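Compound 1 to compound 3: one ester group fewer

The source may report more compounds than this note shows. Statements on the series, on what has been measured and on what is new or still open speak of the compounds shown alone.

In a functional assay on MIA PaCa-2 cells (Homo sapiens) for inhibition, read by MTT assay, with a stated time of 24 h (a higher number here means a weaker inhibitor of growth, a lower number a stronger inhibitor of growth), compound 1 (`N[C@@H](CCC(=O)OC[C@H]1O[C@@H](n2cc(F)c(=O)[nH]c2=O)C[C@@H]1OC(=O)CC[C@H](N)C(=O)O)C(=O)O`) stands at 3300000 nM and compound 2 (`CC(C)[C@H](N)C(=O)OC[C@H]1O[C@@H](n2cc(F)c(=O)[nH]c2=O)C[C@@H]1O`) at 4200000 nM in the same range, the two lying within the scatter of each other. Compound 3 (`N[C@@H](CCC(=O)O[C@H]1C[C@H](n2cc(F)c(=O)[nH]c2=O)O[C@@H]1CO)C(=O)O`) differs from compound 1 by one change (hydrogen in place of (3-amino-3-carboxypropyl)carbonyl on an oxygen on a saturated carbon), hydrogen in place of (3-amino-3-carboxypropyl)carbonyl on an oxygen on a saturated carbon. Among the compounds with values here, no measured pair isolates this change, so the evidence is thin. Like compound 3, compound 2 with 4200000 nM carries one ester group on the shared core, and that value lies within the scatter of compound 1 with its two. In this assay no step beyond the scatter is expected, and the estimated 1.1-fold higher number from compound 1 to compound 3 (0.03 log units; within the scatter) has no firm direction. The expected value for compound 3 is 3500000 nM within a range from 1500000 nM to 8000000 nM in this estimate.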

Compound 3, concentration for 50% growth inhibition: 2500000 nM
Beside the measured number, compound 3's estimate is 1.4-fold (0.15 log units) above it; measured number inside the range.
By their numbers in this assay, from the lowest: compounds 3, 1 and 2 (each within the scatter of the next).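

In this assay, the change from (((3-amino-3-carboxypropyl)carbonyl)oxy)methyl to hydroxymethyl now has a measured step: a 1.3-fold lower number from compound 1 to compound 3 (0.12 log units; within the scatter). Compound 1 and compound 3 therefore cannot be told apart here, and at this position the presence of the (3-amino-3-carboxypropyl)carbonyl group leaves no effect that can be read beyond the scatter. Nothing at hand speaks to what lies behind this result.

As far as these compounds go, whether an acetyl group or a longer saturated carbon chain on this oxygen would give a number beyond the scatter remains open. From the compounds shown here alone, it is also open whether the free amine or the carboxylic acid of the (3-amino-3-carboxypropyl)carbonyl group on the remaining ester matters.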